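Shortening an Ethyl Group to Methyl

The source may report more compounds than this note shows. Statements on the series, on what has been measured and on what is new or still open speak of the compounds shown alone.

Measured so far in a functional assay on L02 cells (Homo sapiens) for inhibition; a lower number here means a stronger inhibitor, a higher number a weaker inhibitor

Compound 1 `CCN(CC)CCNC(=O)CC(CC(=O)NC1Cc2ccccc2C1)c1ccccc1` gives > 100000 nM as a limit of the assay and not a number
Compound 2 `CCN(C(=O)CC(CC(=O)NCCN1CCCCC1)c1ccc(Cl)cc1)C1Cc2ccccc2C1` gives 84200 nM
Compound 3 `CCN(C(=O)CC(CC(=O)NCCN1CCCC1)c1ccc(Cl)cc1)C1Cc2ccccc2C1` gives 54200 nM

Compound 3 stands level with compound 2 since a 1.6-fold lower number from compound 2 to compound 3 (0.19 log units; within the scatter) stays within the scatter. The change to compound 4 `CN(C(=O)CC(CC(=O)NCCN1CCCC1)c1ccc(Cl)cc1)C1Cc2ccccc2C1` reads hydrogen in place of methyl on a saturated chain carbon bound to an amide-type nitrogen or in words hydrogen in place of methyl on a saturated chain carbon bound to an amide-type nitrogen. Within the data shown here, no measured step covers this place. Among the measured compounds shown here, the only step available is a 1.6-fold lower number from compound 2 to compound 3 (0.19 log units; within the scatter) and it concerns pyrrolidin-1-yl in place of piperidin-1-yl elsewhere in the molecule. No step beyond the scatter is therefore expected in this assay and no direction is favoured. The expected step is a 1.0-fold lower number from compound 3 to compound 4 (0.00 log units; within the scatter) as an estimate only. For compound 4 the estimated value is 54000 nM with an expected range from 27000 nM to 100000 nM on repeated measurement.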

Compound 4, half-maximal inhibitory concentration: 81500 nM
For compound 4 the middle estimate is 1.5-fold (0.18 log units) below the measured one; measured number inside the range.
By their numbers in this assay, from the lowest: compounds 3, 4 and 2 (each within the scatter of the next). At a limit, above all of these: compound 1.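

Shortening ethyl to methyl, the only change shown at this place, gives a 1.5-fold higher number from compound 3 to compound 4 (0.18 log units; within the scatter) in this assay. In this one pair, the shorter group therefore leaves the reading within the scatter, though a single pair sets no rule for the series. Compound 1 stands apart as a limit of the assay and not a number: the limit of > 100000 nM in this assay, at which 1 of the 4 values shown sits.

From the compounds shown here alone, whether a longer chain such as propyl, or a chain ending in an amine or a carboxylic acid, would read differently at this place stays open.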